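Benzyl for 4-fluorophenyl on an amide-type nitrogen

The compounds below may be only part of what the source reports. "The series", "measured", "known", "first", "only" and "open" are said of these compounds alone.

compound 1 `CC1=C(/C=C/C(C)=C/C=C/C(C)=C\C(=O)Nc2ccccc2)C(C)(C)CCC1n1ccnc1`: 1900 nM
compound 2 `CC1=C(/C=C/C(C)=C/C=C/C(C)=C\C(=O)Nc2cccc(F)c2)C(C)(C)CCC1n1ccnc1`: 5490 nM
compound 3 `CC1=C(/C=C/C(C)=C/C=C/C(C)=C\C(=O)Nc2ccc(F)cc2)C(C)(C)CCC1n1ccnc1`: 400 nM

All three values come from a functional assay on MCF7 cells (Homo sapiens) for inhibition, read by MTT assay; a higher number here means a weaker inhibitor of growth, a lower number a stronger inhibitor of growth. Compound 3 holds the lowest number of the set, with a 4.8-fold lower number from compound 1 to compound 3 (0.68 log units; beyond the scatter) and a 14-fold lower number from compound 2 to compound 3 (1.14 log units; beyond the scatter).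

The next case is compound 4 `CC1=C(/C=C/C(C)=C/C=C/C(C)=C\C(=O)NCc2ccccc2)C(C)(C)CCC1n1ccnc1`, which carries benzyl in place of 4-fluorophenyl on an amide-type nitrogen.

Within the data shown here, no measured step covers a benzyl group, so the guidance is indirect. Compound 4 has no fluoro, and the step that added one to reach compound 3 was modest, a 4.8-fold lower number from compound 1 to compound 3 (0.68 log units; beyond the scatter). Fluoro does not lower the number in every case, as a 2.9-fold higher number from compound 1 to compound 2 (0.46 log units; beyond the scatter) goes the other way. A modest to large step towards a higher number is therefore expected in this assay, with wide uncertainty. The expected change is a 3.8-fold higher number from compound 3 to compound 4 (0.57 log units; beyond the scatter).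

For compound 4 the estimated value is 1500 nM, with an expected range of 450 nM to 5500 nM.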

Compound 4, concentration for 50% growth inhibition: 9770 nM
Compound 4: the middle estimate sits 6.5-fold (0.81 log units) below what was measured; measured number outside the range, above it.
By their numbers in this assay, from the lowest: compound 3; then compound 1; then compounds 2 and 4 (each within the scatter of the next).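

Lengthening the link to the aromatic ring on the amide-type nitrogen gives a loss even without fluoro in the comparison: for benzyl in place of phenyl in this assay, the change is a 5.1-fold higher number from compound 1 to compound 4 (0.71 log units; beyond the scatter) and counts as modest. The same change from the best compound of the set is larger, at a 24-fold higher number from compound 3 to compound 4 (1.39 log units; beyond the scatter) and removes all of the gain seen with 4-fluorophenyl, whereas the comparison with 3-fluorophenyl gives a 1.8-fold higher number from compound 2 to compound 4 (0.25 log units; within the scatter) and leaves those two compounds indistinguishable in this read-out. (Nothing available here bears on the cause of these steps).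

As far as these compounds go, whether 4-fluorobenzyl would lower the number relative to benzyl, as 4-fluorophenyl does relative to phenyl, remains open. Also open, from the compounds shown here alone, is how 2-phenylethyl, a pyridyl ring or a simple alkyl chain on the amide-type nitrogen would read.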